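Cyclopropyl in Place of Fluoropyridinyl: Expected Permeability

The source may report more compounds than this note shows. Statements on the series, on what has been measured and on what is new or still open speak of the compounds shown alone.

Among the measured compounds shown here, compound 1 `CCCCc1nc(=O)c(S(=O)(=O)c2ccc(-c3ccc(F)nc3)cc2)c(O)n1-c1c(OC)cccc1OC` was tested in an ADME assay for permeability, using PAMPA, at pH 7.4 (on this read-out higher numbers stand for higher permeability and lower numbers for lower permeability), where compound 1 gives 24 nm/s, the higher of the two numbers measured so far; compound 2 `COc1cccc(OC)c1-n1c(COC(C)C)nc(=O)c(S(=O)(=O)c2ccc(-c3ccc(F)nc3)cc2)c1O` gives 4 nm/s, a step of a 6.0-fold lower number from compound 1 to compound 2 (0.78 log units; beyond the scatter). Compound 3 `CCCCc1nc(=O)c(S(=O)(=O)c2ccc(C3CC3)cc2)c(O)n1-c1c(OC)cccc1OC` has not yet been measured; it differs from compound 1 as cyclopropyl in place of 6-fluoropyridin-3-yl on an aromatic carbon. For the measured compounds named here, the only measured step concerns a different part of the shared core, so no measured step bears directly on this change. The expectation for compound 3 therefore rests on compound 1 alone: a step of a 1.5-fold higher number from compound 1 to compound 3 (0.16 log units; within the scatter) is expected, giving an estimated 35 nm/s, with a range from 12 nm/s to 100 nm/s.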

Compound 3, apparent permeability: 22 nm/s
Beside the measured number, compound 3's estimate is 1.6-fold (0.20 log units) above it; low and high end bracket the measured number.
By their numbers in this assay, from the lowest: compound 2; then compounds 3 and 1 (each within the scatter of the next).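

In this assay, putting cyclopropyl in place of 6-fluoropyridin-3-yl on this aromatic carbon gives a 1.1-fold lower number from compound 1 to compound 3 (0.04 log units; within the scatter). The earlier step concerned only another part of the shared core, whereas this one shows that a smaller, non-aromatic ring of carbon only can stand at this position, para to a large group, with no change beyond the scatter. No supporting measurement accounts for this result. On these data alone, whether an amine or a carboxylic acid on this aromatic carbon would read the same remains open. So does whether isopropoxy in place of propyl would give a step of the same size on compound 3.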